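The source may report more compounds than this note shows. Statements on the series, on what has been measured and on what is new or still open speak of the compounds shown alone.

Measured compounds:
- compound 1, `Cc1ccc(-c2ccnc(C(=O)Nc3ccc(Oc4ccnc5[nH]ccc45)cc3)n2)cc1`: 6140 nM
- compound 2, `O=C(Nc1ccc(Oc2ccnc3[nH]ccc23)cc1)c1nccc(-c2cccc(Cl)c2)n1`: 7800 nM
- compound 3, `COc1ccc(-c2cc(C(=O)Nc3ccc(Oc4ccnc5[nH]ccc45)cc3)ncn2)cc1`: 9830 nM

All three values come from a functional assay on PC-3 cells (Homo sapiens) for cytotoxicity, read by MTT assay, with a stated time of 72 h; on this read-out lower numbers stand for stronger inhibition and higher numbers for weaker inhibition. Compound 3 gives the highest of the three numbers, but its distances to compound 2 and to compound 1 both sit within the usual scatter of this assay, so the three compounds cannot be told apart on these numbers. Compound 4, `O=C(Nc1ccc(Oc2ccnc3[nH]ccc23)cc1)c1cc(-c2ccc(Br)cc2)ncn1`, is the next compound to be measured. It differs from compound 3 by bromo in place of methoxy on an aromatic carbon, on an aromatic carbon of a six-membered aromatic ring of carbon only. The only measured step among these compounds is a 1.3-fold higher number from compound 1 to compound 2 (0.10 log units; within the scatter); that step also swaps one group on the same kind of carbon-only aromatic ring and stays within the scatter. With that single small step as a guide, compound 4 is expected to show no step beyond the scatter, so a 1.2-fold lower number from compound 3 to compound 4 (0.09 log units; within the scatter) is the estimate. For compound 4 the estimated value is 8000 nM, with a range from 3000 nM to 25000 nM.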

Compound 4, half-maximal inhibitory concentration: 2610 nM
Estimate against measurement, compound 4: 3.1-fold (0.49 log units) above, outside the stated range (below it).
By their numbers in this assay, from the lowest: compound 4; then compounds 1, 2 and 3 (each within the scatter of the next).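

In this assay the change from 4-methoxyphenyl to 4-bromophenyl gives a 3.8-fold lower number from compound 3 to compound 4 (0.58 log units; beyond the scatter) and is the first step among these compounds to pass beyond the scatter. Within the data shown here, the one earlier step, a 1.3-fold higher number from compound 1 to compound 2 (0.10 log units; within the scatter), also changed a group on a carbon-only aromatic ring but stayed within the scatter, so only this new pair shows that the group at this position, para to a large group, can shift the number measurably. Nothing measured here explains why the number falls with this change.

From the compounds shown here alone, it remains open whether the lower number comes from gaining bromo or from losing methoxy, and whether an amine or a carboxylic acid at this position would move it in the same direction. Going by these compounds, it is also open whether the same swap would give a similar step on the core of compound 1.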